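Sulfonyl-side change on the shared core

A few compounds are considered here, and "the series" means these few. Any claim that something is new, unique, unknown or untested is made for them only; others in the source may bear on it.

For the measured compounds named here, compound 1 `CCN(CC)S(=O)(=O)c1ccc(S(=O)(=O)N2CCC[C@@H](C(=O)N3CCC(F)(F)CC3)C2)cc1` gives 120 nM in a functional assay on BXPC-3 cells (Homo sapiens) for inhibition, read by MTT assay, with a stated time of 7 days (on this read-out higher numbers stand for weaker inhibition and lower numbers for stronger inhibition), the lowest of the two numbers measured so far. Going by the values given here, compound 2 `CCN(CC)S(=O)(=O)c1ccc(S(=O)(=O)N2CCC[C@@H](C(=O)N3CCS(=O)(=O)CC3)C2)cc1` gives 4430 nM in this assay; the only measured step, a 37-fold higher number from compound 1 to compound 2 (1.57 log units; beyond the scatter), alters the amide side of the shared core. Compound 3 `CC(C)S(=O)(=O)c1ccc(S(=O)(=O)N2CCC[C@@H](C(=O)N3CCC(F)(F)CC3)C2)cc1` changes a different place: isopropyl in place of diethylamino on a sulfonyl sulfur. Among the compounds with values here, no measured step touches the sulfonyl sulfur, so that single step sets no direct expectation for this change; it shows only that the series can move sharply with one alteration elsewhere. With the amide side of compound 1 kept intact, the new compound is assumed to stay close to its parent. The expected step is a 1.7-fold higher number from compound 1 to compound 3 (0.22 log units; within the scatter), small and within reach of either direction. Compound 3 is therefore estimated at 200 nM, with a range from 50 nM to 800 nM.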

Compound 3, half-maximal inhibitory concentration: 50 nM
Compound 3: the middle estimate sits 4.0-fold (0.60 log units) above what was measured, within the range that was stated.
By their numbers in this assay, from the lowest: compound 3; then compound 1; then compound 2.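

The sulfonyl sulfur is a second place where the series responds: with the amide side held constant, isopropyl in place of diethylamino gives a measurable change (a 2.4-fold lower number from compound 1 to compound 3 (0.38 log units; beyond the scatter)) in this assay. The nitrogen of diethylsulfamoyl is thus not required to retain activity on this read-out, as isopropylsulfonyl has no nitrogen and fewer heavy atoms, although this step is smaller than the amide-side one (a 37-fold higher number from compound 1 to compound 2 (1.57 log units; beyond the scatter)). No available measurement explains the lower number.

The compounds shown do not separate loss of the nitrogen from loss of heavy atoms; a methyl or cyclopropyl group or a pyrrolidin-1-yl group on the sulfonyl sulfur would bear on this. Going by these compounds, whether isopropyl has the same effect with 1,1-dioxothiomorpholin-4-yl on the carbonyl carbon also remains open.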